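This account rests on a few compounds, and the source may have more. Where it says the series, first, only, none or still open, it means among the compounds named here.

Of the compounds shown here, three have been measured in a functional assay on RAW264.7 cells (Mus musculus) for inhibition, read by Griess assay, with stated times of 3 h and 24 h (a higher number here means a weaker inhibitor, a lower number a stronger inhibitor), and all three sit at the same limit of that assay. Compound 1 `C=C1CC[C@H]2[C@@](C)(CCC(=O)N[C@@]2(C)COC(=O)c2cccnc2)[C@@H]1/C=C/C1=CCOC1=O` carries a pyridin-3-yl group on an ester carbonyl, and in this assay compound 1 gives only the limit > 50000 nM. Compound 2 `C=C1CC[C@H]2[C@@](C)(CCC(=O)N[C@@]2(C)COC(=O)c2ccccc2)[C@@H]1/C=C/C1=CCOC1=O` differs from it by phenyl in place of pyridin-3-yl on a carbonyl carbon. In this assay compound 2 likewise gives only the limit > 50000 nM. The step between them, a step that the two limits leave unreadable from compound 1 to compound 2, therefore cannot be sized, because both values rest at the limit of > 50000 nM in this assay, at which 3 of the 3 values shown sit. Compound 3 `C=C1CC[C@H]2[C@@](C)(CC[C@@H](OC(=O)c3cccnc3)[C@@]2(C)NC=O)[C@@H]1/C=C/C1=CCOC1=O` is built from the same atoms as compound 1, joined differently; the difference between the two cores is not broken down here. In this assay compound 3 also gives only the limit > 50000 nM.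

Compound 4 `C=C1CC[C@H]2[C@@](C)(CC[C@@H](OC(=O)c3ccccc3)[C@@]2(C)NC=O)[C@@H]1/C=C/C1=CCOC1=O` has not yet been measured. It differs from compound 3 by phenyl in place of pyridin-3-yl on a carbonyl carbon, the same kind of change that separates compound 1 from compound 2; the place is described in the same words for both pairs. Since compound 3 gives only a limit > 50000 nM in this assay, and the change from compound 1 to compound 2 left both partners at the same limit, the expected step that the limit leaves unreadable from compound 3 to compound 4 is read as no measurable movement. The estimate for compound 4 in this assay is accordingly 60000 nM, with an expected range from 30000 nM to 200000 nM, and most likely the assay will again report only a limit.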

Compound 4, half-maximal inhibitory concentration: 50000 nM
Beside the measured number, compound 4's estimate is 1.2-fold (0.08 log units) above it, within the range that was stated.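

In this assay compound 4 gives 50000 nM, a measured number. Compound 3 gives > 50000 nM, which is a limit of the assay and not a number. Carrying phenyl in place of pyridin-3-yl to this second core yields a number no higher from compound 3 to compound 4 (the limit leaves the size open), so the change shows no strong inhibitor on this core, but neither this step nor the one on the core of compound 1 can be sized, and the data do not show whether the change acts alike on both cores: the limit of > 50000 nM in this assay, at which 3 of the 4 values shown sit.

The compounds shown leave open whether another group on that carbonyl carbon, such as an amine, a carboxylic acid or a longer alkyl chain, would give a value well clear of the limit in this assay. They also leave open how the two cores compare once a group gives readable numbers on both of them.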